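The compounds below may be only part of what the source reports. "The series", "measured", "known", "first", "only" and "open" are said of these compounds alone.

Measured compounds in a functional assay on isolated protein for inhibition of Glucose-dependent insulinotropic receptor (Rattus norvegicus), read by HTRF and cAMP accumulation; on this read-out lower numbers stand for smaller maximal responses and higher numbers for larger maximal responses:
compound 1, `Cc1nc(S(C)(=O)=O)ccc1Oc1ncnc(OC2CCN(C(=O)OC(C)(C)C#N)CC2)c1F`: 97%
compound 2, `Cc1nc(S(C)(=O)=O)ccc1Oc1ncnc(OC2CCN(C(=O)SC3CC3)CC2)c1F`: 80%
compound 3, `CCC(F)(F)C(=O)N1CCC(Oc2ncnc(Oc3ccc(S(C)(=O)=O)nc3C)c2F)CC1`: 90%

Compound 2 stands lowest of the three in this assay. For the measured compounds named here, its nearest neighbour is compound 3, a number 10 percentage points higher from compound 2 to compound 3 (within the scatter), a gap within the scatter; its furthest is compound 1, a number 17 percentage points lower from compound 1 to compound 2 (beyond the scatter), the only step in the set that lies beyond the scatter.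

Compound 4, `Cc1nc(S(C)(=O)=O)ccc1Oc1ncnc(OC2CCN(C(=O)c3nc(C(C)(C)F)no3)CC2)c1F`, is not yet measured. Relative to compound 2 the change is a group of 9 heavy atoms (5 carbon, 2 nitrogen, 1 oxygen, 1 fluorine; one five-membered aromatic ring with 3 hetero atoms) in place of a group of 4 heavy atoms (3 carbon, 1 sulfur; one three-membered non-aromatic ring of carbon only), on a carbonyl carbon

All three measured steps exchange the group on the same carbonyl carbon: a number 17 percentage points lower from compound 1 to compound 2 (beyond the scatter), a number 7 percentage points lower from compound 1 to compound 3 (within the scatter) and a number 10 percentage points higher from compound 2 to compound 3 (within the scatter). Two of them lie within the scatter and the third is modest, so the efficacy in this assay has so far moved little with what sits on that carbonyl carbon. Compound 2 lies at the lower edge of the measured band. The step is therefore expected to be small and upward, toward the middle of that band, a number 9 percentage points higher from compound 2 to compound 4 (within the scatter). For compound 4 the estimate in this assay is 89%, with a range from 76% to 100%.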

Compound 4, largest response reached (reported as efficacy), in percent of the reference or control that the assay uses: 84%
Compound 4: middle estimate off by 5 percentage points, on the high side; measured number inside the range.
By their numbers in this assay, from the lowest: compounds 2, 4, 3 and 1 (each within the scatter of the next, the first and the last beyond it).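

In this assay the carbonyl carbon takes the larger group with one five-membered aromatic ring with 3 hetero atoms without any clear shift from the two closest compounds: a number 4 percentage points higher from compound 2 to compound 4 (within the scatter) and a number 6 percentage points lower from compound 3 to compound 4 (within the scatter). Only a number 13 percentage points lower from compound 1 to compound 4 (beyond the scatter) lies beyond the scatter, so compound 1 stands apart from both compound 2 and compound 4, while compound 3, which goes against any clean split, lies within the scatter of all three others. For the compounds shown here, neither the size of the group nor the presence of an aromatic ring separates these compounds so far, and no supporting data bear on the reason for these steps.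

From the compounds shown here alone, whether an amine or a carboxylic acid on this carbonyl carbon would give a step of another size remains open. Also open, going by these compounds, is whether changes to the shared core would move the response further than these exchanges.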